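Working notes: from compound 3 to compound 4

The source may report more compounds than this note shows. Statements on the series, on what has been measured and on what is new or still open speak of the compounds shown alone.

Compound 1 (`COc1ccc(C)cc1-c1cnc(OCCCCc2ccccc2)n1C`): 28000 nM
Compound 2 (`C=CCCCCOc1cc(F)ccc1-c1cnc(OCCC=C)n1C`): 59000 nM
Compound 3 (`Cn1c(-c2ccccc2O)cnc1S(=O)(=O)c1ccccc1`): > 100000 nM (a limit, not a number)

Within the data shown here, all three values come from a functional assay on MCF7 cells (Homo sapiens) for inhibition, read by colorimetric assay and MTT assay, with a stated time of 72 h (on this read-out lower numbers stand for stronger inhibition and higher numbers for weaker inhibition), and no compound in this set has been tested elsewhere. Compound 3 stands at the limit of > 100000 nM in this assay, at which 1 of the 3 values shown sits, and so carries a limit and no number.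

Compound 4 (`C=CCCOc1ccccc1-c1cnc(S(=O)(=O)c2ccccc2)n1C`) has but-3-en-1-yl in place of hydrogen on an oxygen on an aromatic ring of compound 3 (but-3-en-1-yl in place of hydrogen on an oxygen on an aromatic ring). The hydroxy thus becomes (but-3-en-1-yl)oxy.

Among the measured compounds shown here, no measured pair here differs in one place, so no step gives the size of this change directly. The closest guide is compound 2 (59000 nM), which also has a chain on an oxygen on an aromatic ring and returns a number. A small to moderate move towards stronger inhibition in this assay is therefore expected (an at least 1.6-fold lower number from compound 3 to compound 4 (0.22 log units; that floor lies within the scatter)), although another limit remains possible. For compound 4 the estimate is 60000 nM (expected range 25000 nM to 130000 nM).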

Compound 4, half-maximal inhibitory concentration: 67000 nM
The estimate for compound 4 lay 1.1-fold (0.05 log units) below the measured number, within the range that was stated.
By their numbers in this assay, from the lowest: compound 1; then compounds 2 and 4 (each within the scatter of the next). At a limit, above all of these: compound 3.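

In this assay, placing but-3-en-1-yl on the oxygen on an aromatic ring, so that hydroxy becomes (but-3-en-1-yl)oxy, gives an at least 1.4-fold lower number from compound 3 to compound 4 (0.17 log units; that floor lies within the scatter). Among these compounds, this is the first pair that differs in one place, so this change can be read on its own, although the printed floor does not by itself go beyond the usual scatter. The step can be read only as a floor because compound 3 carries a limit and no number: the limit of > 100000 nM in this assay, at which 1 of the 4 values shown sits.

The compounds shown leave open how the read-out in this assay follows the group on this oxygen, for example whether a methyl, a saturated butyl or a longer chain would read like but-3-en-1-yl. Also open, from the compounds shown here alone, is how a chain ending in an amine or a carboxylic acid would read at this position.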